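The source may report more compounds than this note shows. Statements on the series, on what has been measured and on what is new or still open speak of the compounds shown alone.

Three close relatives built on one shared core have been tested in a functional assay on CCRF-CEM cells (Homo sapiens) for antiproliferative activity, read by cell counting, with a stated time of 72 h; a higher number here means a weaker inhibitor, a lower number a stronger inhibitor. Compound 1 `C#C[C@@]1(O)[C@@H](CO)O[C@@H](n2cc(Cl)c3c(N)ncnc32)[C@@H]1O` gives 12 nM; compound 2 `C#C[C@@]1(O)[C@@H](CO)O[C@@H](n2cc(I)c3c(N)ncnc32)[C@@H]1O` gives 120 nM; compound 3 `C#C[C@@]1(O)[C@@H](CO)O[C@@H](n2cc(C(F)(F)F)c3c(N)ncnc32)[C@@H]1O` gives 360 nM, the highest number of the three and so the weakest inhibitor among them. Putting iodo in place of chloro gave a 10-fold higher number from compound 1 to compound 2 (1.00 log units; beyond the scatter), trifluoromethyl in place of chloro gave a 30-fold higher number from compound 1 to compound 3 (1.48 log units; beyond the scatter), and trifluoromethyl in place of iodo gave a 3.0-fold higher number from compound 2 to compound 3 (0.48 log units; beyond the scatter). Compound 4 `C#Cc1cn([C@@H]2O[C@H](CO)[C@](O)(C#C)[C@H]2O)c2ncnc(N)c12` differs from compound 3 by ethynyl in place of trifluoromethyl on an aromatic carbon. Within the data shown here, every step so far shows that what sits on this aromatic carbon matters, and both steps ending at trifluoromethyl run upward, so leaving it behind is expected to lower the number in this assay by about an 18-fold lower number from compound 3 to compound 4 (1.26 log units; beyond the scatter). Compound 4 is therefore estimated at 20 nM, within 4 nM to 100 nM.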

Compound 4, half-maximal inhibitory concentration: 63000 nM
Compound 4: the middle estimate sits 3200-fold (3.50 log units) below what was measured; measured number outside the range, above it.
By their numbers in this assay, from the lowest: compound 1; then compound 2; then compound 3; then compound 4.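

Ethynyl on this aromatic carbon brings a far larger change in this assay than any swap among the earlier groups: a 180-fold higher number from compound 3 to compound 4 (2.24 log units; beyond the scatter) and a 530-fold higher number from compound 2 to compound 4 (2.72 log units; beyond the scatter) and a 5300-fold higher number from compound 1 to compound 4 (3.72 log units; beyond the scatter) are all large. The position accepts chloro, iodo and trifluoromethyl far better than ethynyl, although ethynyl has fewer heavy atoms than trifluoromethyl, so size by atom count does not order these four groups. Nothing available here accounts for this loss. On these data alone, what a methyl, an amine or a nitrile would give on this carbon remains open, as does whether the triple bond itself drives the drop.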